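The source may report more compounds than this note shows. Statements on the series, on what has been measured and on what is new or still open speak of the compounds shown alone.

Of the compounds shown here, three sharing one core have been measured in a functional assay on HepG2 cells (Homo sapiens) for inhibition, read by MTT assay; a higher number here means a weaker inhibitor, a lower number a stronger inhibitor. Compound 1 `COc1cc2ncnc(Nc3ccc(NC(=O)c4ccc(C)cc4)cc3)c2cc1OC`, with 4-methylphenyl on the carbonyl carbon, gives 25000 nM. Compound 3 `COc1cc2ncnc(Nc3ccc(NC(=O)c4cccc(I)c4)cc3)c2cc1OC`, with 3-iodophenyl in that place, gives 28000 nM. That swap amounts to a 1.1-fold higher number from compound 1 to compound 3 (0.05 log units; within the scatter), so these two numbers cannot be told apart. The value of compound 2 `COc1cc2ncnc(Nc3ccc(NC(=O)c4ccccc4OC)cc3)c2cc1OC`, which carries 2-methoxyphenyl, is a limit of the assay: > 100000 nM. Measured against that limit, the steps are an at least 4.0-fold higher number from compound 1 to compound 2 (0.60 log units; beyond the scatter) and an at least 3.5-fold lower number from compound 2 to compound 3 (0.55 log units; beyond the scatter).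

Within the data shown here, compound 4 `COc1cc2ncnc(Nc3ccc(NC(=O)c4cc(F)ccc4Br)cc3)c2cc1OC` is the next to be read, and it changes only this group: 2-bromo-5-fluorophenyl in place of 3-iodophenyl on a carbonyl carbon. In words, 2-bromo-5-fluorophenyl stands in place of 3-iodophenyl on a carbonyl carbon. Two measured steps guide the expectation. Compound 1 and compound 3 show, through a 1.1-fold higher number from compound 1 to compound 3 (0.05 log units; within the scatter), that a change of this group need not move the number. Among the measured compounds shown here, compound 2, the only measured compound whose group name also starts at 2, shows through an at least 3.5-fold lower number from compound 2 to compound 3 (0.55 log units; beyond the scatter) that it can. A modest move towards a higher number is therefore expected, resting on compound 2 alone. The estimated change is a 1.8-fold higher number from compound 3 to compound 4 (0.25 log units; within the scatter). For compound 4 the expected value is 50000 nM, with an estimated range from 18000 nM to 100000 nM.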

Compound 4, half-maximal inhibitory concentration: 22000 nM
Beside the measured number, compound 4's estimate is 2.3-fold (0.36 log units) above it; the range from low to high includes it.
By their numbers in this assay, from the lowest: compounds 4, 1 and 3 (each within the scatter of the next). At a limit, above all of these: compound 2.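

Compound 4 shows that a group whose name starts at 2 does not by itself go with a limit in this assay: the step from the 2-methoxyphenyl group to 2-bromo-5-fluorophenyl is an at least 4.5-fold lower number from compound 2 to compound 4 (0.65 log units; beyond the scatter). The place on the carbonyl carbon also tolerates a group carrying two halogens without a readable move, with a 1.3-fold lower number from compound 3 to compound 4 (0.10 log units; within the scatter) and a 1.1-fold lower number from compound 1 to compound 4 (0.06 log units; within the scatter), so 4-methylphenyl, 3-iodophenyl and 2-bromo-5-fluorophenyl cannot be told apart here. Compound 2 is the one compound that goes against this flat picture, and its value is a limit, so the full size of its steps cannot be read: the limit of > 100000 nM in this assay, at which 1 of the 4 values shown sits.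

As far as these compounds go, what separates 2-methoxyphenyl from 2-bromo-5-fluorophenyl stays open, as does whether the bromine or the fluorine of compound 4 matters on its own. Also open, from the compounds shown here alone, is what an amine, a carboxylic acid or a longer chain on the carbonyl carbon would give in place of these aromatic groups, and whether any such group would move the number beyond the scatter in the stronger direction.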